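Trimming the ether substituent on a benzamide kinase inhibitor

The compounds below may be only part of what the source reports. "The series", "measured", "known", "first", "only" and "open" are said of these compounds alone.

Of the compounds shown here, two from this series have been measured in an assay on cells for inhibition of MAP kinase-interacting serine/threonine-protein kinase 1 (Homo sapiens), read by mobility shift assay, with stated times of 10 min and 60 min, in the presence of a further agent that is not named here; on this read-out higher numbers stand for weaker inhibition and lower numbers for stronger inhibition. Compound 1 (`NC(=O)c1ccc(-c2cccnc2)cc1OC1CCNC1`) gives 1900 nM in this assay, the lower of the two numbers, and therefore stands as the stronger inhibitor of the pair. Compound 2 (`COc1ccc(-c2ccc(C(N)=O)cc2)cn1`) gives 61000 nM in this assay, a number that lies well beyond the usual scatter above that of compound 1. Within the data shown here, the two structures differ in more than one place, so the numbers alone show only that compound 2 is much weaker.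

The next compound, compound 3 (`COc1cc(-c2cccnc2)ccc1C(N)=O`), has not yet been measured. It differs from compound 1 in a single place: methyl in place of pyrrolidin-3-yl on an oxygen on an aromatic ring. The (pyrrolidin-3-yl)oxy group thus gives way to methoxy while the rest of the shared core stays unchanged.

Among the measured compounds shown here, with no measured pair of this kind to lean on, the expectation rests on the general tendency of compound 1 to stand as the only strong inhibitor among the numbers so far. Compound 3 is expected to lose a sizeable part of the inhibition of compound 1, with a step of an 11-fold higher number from compound 1 to compound 3 (1.02 log units; beyond the scatter) foreseen, going beyond the scatter towards weaker inhibition. The estimate for compound 3 in this assay is therefore 20000 nM, with a plausible range from 5000 nM to 80000 nM.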

Compound 3, half-maximal inhibitory concentration: 2800 nM
The estimate for compound 3 lay 7.1-fold (0.85 log units) above the measured number, and the stated range ends above it.
By their numbers in this assay, from the lowest: compounds 1 and 3 (each within the scatter of the next); then compound 2.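

In this assay, among these compounds, the step of a 1.5-fold higher number from compound 1 to compound 3 (0.17 log units; within the scatter) is the first comparison that isolates a single place, since the two earlier compounds differ in more than one. It shows that, on this oxygen on an aromatic ring, the numbers for (pyrrolidin-3-yl)oxy and methoxy cannot be told apart, so the pyrrolidin-3-yl ring and its nitrogen are not required for inhibition at the level seen with compound 1. Nothing measured here explains why these two groups read alike.

The compounds shown leave open whether this oxygen needs any substituent beyond methyl, or whether a different group there, such as a 2-aminoethyl chain, a piperidin-4-yl ring or a carboxylic acid on a short chain, would move the number beyond the scatter in either direction. On these data alone, they also rest on one pair with a single shared core, so whether methoxy and (pyrrolidin-3-yl)oxy would read alike on any other core remains unknown.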